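Replacing bromo with methoxy on compound 1

The compounds below may be only part of what the source reports. "The series", "measured", "known", "first", "only" and "open" are said of these compounds alone.

Compound 1 `Cn1c([N+](=O)[O-])cnc1/C=C/c1cccc(Br)c1` was tested in an ADME assay on HeLa cells (Homo sapiens) for cytotoxicity, read by resazurin assay, with a stated time of 2 days (on this read-out lower numbers stand for stronger inhibition and higher numbers for weaker inhibition), and in this test compound 1 gives 87100 nM. Compound 2 `Cn1c([N+](=O)[O-])cnc1/C=C/c1ccccc1Cl` returned no number, only a limit of the assay, > 100000 nM. Within the data shown here, compound 1 therefore holds the only true number among the measured compounds, and no step between measured compounds is available to show how large a single change can be.

Compound 3 `COc1cccc(/C=C/c2ncc([N+](=O)[O-])n2C)c1` keeps the core of compound 1 and differs from it in one place: methoxy in place of bromo on an aromatic carbon. Methoxy stands in place of bromo on an aromatic carbon, meta to a large group.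

Among the measured compounds shown here, with no measured step to draw on, no shift beyond the usual scatter is expected in this assay, and the expectation rests on compound 1 at 87100 nM. The assay may well report only a limit again, as it did for compound 2. The expected change is a 1.1-fold higher number from compound 1 to compound 3 (0.04 log units; within the scatter). For compound 3 the estimated value is 95000 nM, with an expected range from 45000 nM to 180000 nM.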

Compound 3, half-maximal inhibitory concentration: > 100000 nM
Compound 3 was reported as a limit (the forecaster's own chance of this, stated with the estimate: 45%); middle value at least 1.0-fold (0.02 log units) from the limit.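

Among these compounds, the exchange on this aromatic carbon, meta to a large group, provides the first step between two measured compounds in this assay and gives an at least 1.1-fold higher number from compound 1 to compound 3 (0.05 log units; that floor lies within the scatter) with methoxy in place of bromo. Compound 3 is reported only as a limit of > 100000 nM and not as a number. The step is therefore only a floor, and it does not set methoxy apart from bromo at this place, with the values of the series gathering at one edge of the read-out: the limit of > 100000 nM in this assay, at which 2 of the 3 values shown sit.

On these data alone, how far compound 3 actually lies from compound 1 stays open, since a limit gives no true size for this step and a single exchange gives no trend for this position. Also open, as far as these compounds go, is whether an amine, a carboxylic acid or a longer chain such as ethoxy at the same aromatic carbon would give a true number in this assay and so show whether this position can move the read-out at all.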